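Formyl in place of ring hydrogen on compound 1

The compounds below may be only part of what the source reports. "The series", "measured", "known", "first", "only" and "open" are said of these compounds alone.

Working notes on the series. Compound 1 `CN(c1ccncc1)n1cccc1` is known in a functional assay on the whole organism with Mus musculus as the target (on this read-out higher numbers stand for an effect only at larger amounts of compound and lower numbers for an effect already at smaller amounts), only to a limit: in this assay compound 1 gives > 20 mg/kg, a limit of the assay and not a number. Going by the values given here, the single measured neighbour is compound 2 `C#CCN(c1ccncc1)n1cccc1`, carrying ethynyl in place of hydrogen on a saturated chain carbon bound to a nitrogen on an aromatic ring. In this assay compound 2 gives > 20 mg/kg, again a limit. The resulting step that the two limits leave unreadable from compound 1 to compound 2 therefore carries no readable size; what is known is the limit of > 20 mg/kg in this assay, at which 2 of the 2 values shown sit.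

Compound 3 `CN(c1ccncc1)n1cccc1C=O` differs from compound 1 by formyl in place of hydrogen on an aromatic carbon. No measured step touches the five-membered ring, so nothing shown predicts the direction or size of the change in this assay. Given that the limit of > 20 mg/kg in this assay, at which 2 of the 2 values shown sit, holds for every value so far, compound 3 is expected to give 30 mg/kg, with a range from 10 mg/kg to 100 mg/kg, a step that the limit leaves unreadable from compound 1 to compound 3 that is estimated, not measured, and most likely to return as another limit.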

Compound 3, dose for half-maximal effect: > 20 mg/kg
Compound 3 gave a limit, no number (the forecaster's own chance of this, stated with the estimate: 70%); the middle value is on the limit's open side.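

In this assay, going by these compounds alone, compound 3 gives > 20 mg/kg, a limit and not a number, so no step from compound 1 to compound 3 can be read. The compounds shown leave open what size of effect formyl in place of hydrogen on an aromatic carbon has, since none yields a number: the limit of > 20 mg/kg in this assay, at which 3 of the 3 values shown sit.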